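Compound 3 to compound 4: 3,4,5-trimethoxyphenyl replaces 4-fluorophenyl

The compounds below may be only part of what the source reports. "The series", "measured", "known", "first", "only" and "open" are said of these compounds alone.

Values in a functional assay on A549 cells (Homo sapiens) for inhibition, read by MTT assay, with a stated time of 48 h; on this read-out lower numbers stand for stronger inhibition of growth and higher numbers for weaker inhibition of growth:
compound 1 `COc1ccc(C(=O)N2N=C(c3ccccc3)CC2c2cn(C)c3ccccc23)cn1`: 3040 nM
compound 2 `Cc1ccc(C(=O)N2N=C(c3ccccc3)CC2c2cn(C)c3ccccc23)cn1`: 1190 nM
compound 3 `Cn1cc(C2CC(c3ccc(F)cc3)=NN2C(=O)c2cccnc2)c2cc(Br)ccc21`: 1380 nM

In this assay, compound 3 lies within the scatter of compound 2 and gives a lower number than compound 1. Compound 4 `COc1cc(C2=NN(C(=O)c3cccnc3)C(c3cn(C)c4ccc(Br)cc34)C2)cc(OC)c1OC` differs from it as follows: 3,4,5-trimethoxyphenyl in place of 4-fluorophenyl on a carbon with a double bond to nitrogen. The group sits on a carbon with a double bond to nitrogen. Going by the values given here, the only measured step is a 2.6-fold lower number from compound 1 to compound 2 (0.41 log units; beyond the scatter), for methyl in place of methoxy on an aromatic carbon. It is modest and concerns a different group, so it offers only a weak hint. From the compounds shown here alone, no step beyond the scatter is expected in this assay, and the direction stays open. The estimated outcome is a 1.1-fold lower number from compound 3 to compound 4 (0.04 log units; within the scatter). For compound 4 the expected value is 1250 nM, with an estimated range of 400 nM to 3900 nM.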

Compound 4, concentration for 50% growth inhibition: > 10000 nM
Compound 4: a limit, no number (the forecaster's own chance of this, stated with the estimate: 3%); at least 8.0-fold (0.90 log units) between middle value and limit.
By their numbers in this assay, from the lowest: compounds 2 and 3 (each within the scatter of the next); then compound 1. At a limit, above all of these: compound 4.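

In this assay compound 4 gives > 10000 nM, which is a limit and not a number. The group on a carbon with a double bond to nitrogen clearly matters in this series: 3,4,5-trimethoxyphenyl in place of 4-fluorophenyl gives an at least 7.2-fold higher number from compound 3 to compound 4 (0.86 log units; beyond the scatter). The true size of that step stays unknown, because one end of it is a limit: the limit of > 10000 nM in this assay, at which 1 of the 4 values shown sits.

Open, from the compounds shown here alone, is whether the methoxy groups as such or their number drive this step. A 4-methoxyphenyl or 3,5-dimethoxyphenyl group at this place would separate the two.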